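The compounds below may be only part of what the source reports. "The series", "measured", "known", "first", "only" and "open" are said of these compounds alone.

In a functional assay on MGC-803 cells (Homo sapiens) for antiproliferative activity, read by MTT assay, with a stated time of 48 h (on this read-out higher numbers stand for weaker inhibition and lower numbers for stronger inhibition), the three measured compounds stand as follows:

Compound 1 `Cc1ccc(NC(=O)Nc2cccc(CNc3nccnc3Cl)c2)cc1C` gives 9870 nM.
Compound 2 `O=C(Nc1cccc(CNc2nccnc2Cl)c1)Nc1ccc(Cl)cc1Br` gives 7480 nM.
Compound 3 `O=C(Nc1cccc(CNc2nccnc2Cl)c1)Nc1ccc(F)c(Cl)c1` gives 5020 nM.

Compound 3 shows the lowest number of the three, yet the steps to it are small: a 1.5-fold lower number from compound 2 to compound 3 (0.17 log units; within the scatter) and a 2.0-fold lower number from compound 1 to compound 3 (0.29 log units; within the scatter), both within the scatter, so the three cannot be ordered. Compound 4 `Cc1cccc(NC(=O)Nc2cccc(CNc3nccnc3Cl)c2)c1` differs from compound 3 by 3-methylphenyl in place of 3-chloro-4-fluorophenyl on an amide-type nitrogen. Every measured step swaps the aryl group on this amide-type nitrogen, and none leaves the scatter, including a 1.3-fold lower number from compound 1 to compound 2 (0.12 log units; within the scatter). Compound 1, carrying 3,4-dimethylphenyl, is the nearest comparison for compound 4, so a slight rise toward that value is expected, a 1.6-fold higher number from compound 3 to compound 4 (0.20 log units; within the scatter), still within the scatter. Compound 4 is therefore estimated at 8000 nM, ranging from 3500 nM to 18000 nM.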

Compound 4, half-maximal inhibitory concentration: 14600 nM
Beside the measured number, compound 4's estimate is 1.8-fold (0.26 log units) below it, within the range that was stated.
By their numbers in this assay, from the lowest: compounds 3, 2, 1 and 4 (each within the scatter of the next, the first and the last beyond it).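

In this assay, a swap of the aryl group on the amide-type nitrogen now gives a step beyond the scatter, 3-methylphenyl in place of 3-chloro-4-fluorophenyl (a 2.9-fold higher number from compound 3 to compound 4 (0.46 log units; beyond the scatter)). The other two new steps stay within the scatter (a 2.0-fold higher number from compound 2 to compound 4 (0.29 log units; within the scatter)) and (a 1.5-fold higher number from compound 1 to compound 4 (0.17 log units; within the scatter)), so only compound 3 and compound 4 are separated. Nothing available explains this step. As far as these compounds go, it remains open whether 3-chlorophenyl or 4-fluorophenyl would give a number like that of compound 3, and how an aryl group carrying an amine or a carboxylic acid would read.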